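A trifluoromethylphenyl swap on a core held at the limit

A few compounds are considered here, and "the series" means these few. Any claim that something is new, unique, unknown or untested is made for them only; others in the source may bear on it.

Compound 1 `CCOC(=O)C1=Cc2ccccc2OC1(OCc1cc(-c2ccc(F)cc2F)no1)C(F)(F)F` was tested in a functional assay on DU-145 cells (Homo sapiens) for inhibition, read by MTT assay, with a stated time of 24 h; a lower number here means a stronger inhibitor, a higher number a weaker inhibitor. Compound 1 gives only a limit there, > 150000 nM, and not a number. Compound 3 `O=C(O)C1=Cc2ccccc2OC1(OCc1cc(-c2ccc(F)cc2F)no1)C(F)(F)F` likewise gives only a limit, > 150000 nM. The step that the two limits leave unreadable from compound 1 to compound 3 is therefore unreadable, resting on (the limit of > 150000 nM in this assay, at which 2 of the 3 values shown sit). Going by the values given here, compound 2 `CCOC(=O)C1=Cc2ccccc2OC1(OCc1cn(CC(=O)Nc2ccc(OC)cc2)nn1)C(F)(F)F` is the only one with a number, giving 32700 nM in this assay. Compound 4 `CCOC(=O)C1=Cc2ccccc2OC1(OCc1cc(-c2cccc(C(F)(F)F)c2)no1)C(F)(F)F` has not been measured. It differs from compound 1 by 3-(trifluoromethyl)phenyl in place of 2,4-difluorophenyl on an aromatic carbon. Among the compounds with values here, no measured step shares this change, so the expectation for compound 4 rests solely on where compound 1 stands. Compound 4 is therefore expected to stay weak, with an estimated 120000 nM (range 30000 nM to 300000 nM). The expected step of an at least 1.2-fold lower number from compound 1 to compound 4 (0.09 log units; that floor lies within the scatter) is thus small, if readable at all.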

Compound 4, half-maximal inhibitory concentration: 57300 nM
Beside the measured number, compound 4's estimate is 2.1-fold (0.32 log units) above it; the range from low to high includes it.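

At this position, on an aromatic carbon next to the ring nitrogen, the aryl group alone can bring a reading off the limit: 3-(trifluoromethyl)phenyl in place of 2,4-difluorophenyl gives an at least 2.6-fold lower number from compound 1 to compound 4 (0.41 log units; beyond the scatter). Going by these compounds alone, with the rest of compound 1 unchanged, this is the first readable effect of a change at this position. Its size is only a floor, since compound 1 gives a limit and not a number: the limit of > 150000 nM in this assay, at which 2 of the 4 values shown sit.

As far as these compounds go, it remains open whether a phenyl group bearing an amine here would lower the number further in this assay. From the compounds shown here alone, it is also open whether the trifluoromethyl group needs this placement on the phenyl ring.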